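Fluoro for Hydrogen on the Anilide of Compound 2

The source may hold more compounds than are shown below. What is called first, only, known or untested is meant among the compounds shown, and "the series" means these compounds.

Measured compounds in this study:
Compound 1 `O=C(COc1ccc2c(=O)cc(-c3ccccc3)oc2c1)Nc1ccc2ccccc2c1` — in a functional assay on NCI-H661 cells (Homo sapiens) for antiproliferative activity, read by MTT assay, with a stated time of 72 h (a lower number here means a stronger inhibitor of growth, a higher number a weaker inhibitor of growth), compound 1 gives only a limit, > 10000 nM.
Compound 2 `O=C(COc1ccc2c(=O)cc(-c3ccccc3)oc2c1)Nc1ccccc1` — in this assay compound 2 gives only a limit, > 10000 nM.

Both measured values sit at the limit of > 10000 nM in this assay, at which 2 of the 2 values shown sit, so neither is a number. Going by the values given here, the single measured step, a step that the two limits leave unreadable from compound 1 to compound 2, concerns the group on the amide-type nitrogen, and its size cannot be read because the limit of > 10000 nM in this assay, at which 2 of the 2 values shown sit, holds both of its ends. Compound 2 therefore stands at the limit, with no number of its own and no measured neighbour that gives one.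

Compound 3 `O=C(COc1ccc2c(=O)cc(-c3ccccc3)oc2c1)Nc1ccc(F)cc1` has not yet been measured in this assay. It differs from compound 2 by fluoro in place of hydrogen on an aromatic carbon. Among the compounds with values here, no measured step in this set involves such a change, and the one step that does exist is unreadable, so nothing here points to a change beyond the scatter in either direction. The step that the limit leaves unreadable from compound 2 to compound 3 is expected to stay within the scatter. Compound 3 is estimated at 15000 nM, with a range from 5000 nM to 50000 nM, and most likely reported as a limit again.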

Compound 3, concentration for 50% growth inhibition: 5770 nM
Compound 3: the middle estimate sits 2.6-fold (0.41 log units) above what was measured; the range from low to high includes it.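

In this assay, going by these compounds alone, compound 3 gives 5770 nM, the first reading that is a number and not a limit, so this place on the anilide ring can carry a group that brings growth inhibition within the range of the assay. Fluoro on the aromatic carbon, para to a large group, gives an at least 1.7-fold lower number from compound 2 to compound 3 (0.23 log units; that floor lies within the scatter), and 4-fluorophenyl in place of naphthalen-2-yl on the amide-type nitrogen gives an at least 1.7-fold lower number from compound 1 to compound 3 (0.23 log units; that floor lies within the scatter). Neither step is shown to exceed the usual scatter, and neither these true sizes nor the step between compound 1 and compound 2 can be read, because compound 1 and compound 2 both rest on a limit: the limit of > 10000 nM in this assay, at which 2 of the 3 values shown sit.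

As far as these compounds go, it remains open whether the reading of compound 3 is tied to fluoro, or whether chloro, methoxy or an amine in the same place would also give a number. From the compounds shown here alone, it is equally open whether a longer chain between the amide and the shared core would keep that reading, or how the 4-fluorophenyl amide would behave with a carboxylic acid added to the core.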